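Cyclopropyl for cyclobutyl on the amine: notes on compound 4

The source may hold more compounds than are shown below. What is called first, only, known or untested is meant among the compounds shown, and "the series" means these compounds.

Measured so far in a functional assay on SK-OV-3 cells (Homo sapiens) for inhibition, read by CCK-8 assay, with a stated time of 70 h; a higher number here means a weaker inhibitor, a lower number a stronger inhibitor:
- compound 1 `c1ccc(COc2ccc(OCCOCCOC3CCCC3)cc2)cc1` gives > 100000 nM as a limit of the assay, not a number
- compound 2 `c1ccc(COc2ccc(OCCOCCNc3cc[nH]c3)cc2)cc1` gives 11300 nM
- compound 3 `c1ccc(COc2ccc(OCCOCCNC3CCC3)cc2)cc1` gives 25000 nM

Compound 3 holds the higher of the two true numbers, with a 2.2-fold higher number from compound 2 to compound 3 (0.34 log units; beyond the scatter) as the gap to its nearest neighbour. Compound 4 `c1ccc(COc2ccc(OCCOCCNC3CC3)cc2)cc1` carries cyclopropyl in place of cyclobutyl on an amine nitrogen, the change being cyclopropyl in place of cyclobutyl on an amine nitrogen with the rest of the structure kept.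

For the measured compounds named here, the closest precedent is the change on the same amine nitrogen, a 2.2-fold higher number from compound 2 to compound 3 (0.34 log units; beyond the scatter) and only modest. The other relevant step, an at least 4.0-fold lower number from compound 1 to compound 3 (0.60 log units; beyond the scatter), starts from a limit and also alters the link to the chain, so it gives only a bound.

The swap of cyclobutyl for cyclopropyl is a smaller change than the one behind a 2.2-fold higher number from compound 2 to compound 3 (0.34 log units; beyond the scatter) and no step beyond the scatter is therefore expected. In this assay the expected outcome is no change at the digits printed from compound 3 to compound 4 (within the scatter) for this pair.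

For compound 4 the estimated value is 25000 nM with an expected range of 10000 nM to 60000 nM in this series.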

Compound 4, half-maximal inhibitory concentration: 47200 nM
For compound 4 the middle estimate is 1.9-fold (0.28 log units) below the measured one, within the range that was stated.
By their numbers in this assay, from the lowest: compound 2; then compounds 3 and 4 (each within the scatter of the next). At a limit, above all of these: compound 1.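

In this assay, cyclopropyl in place of cyclobutyl on the amine nitrogen gives a 1.9-fold higher number from compound 3 to compound 4 (0.28 log units; within the scatter), so these two saturated rings are not told apart at this position. For the compounds shown here, the 1H-pyrrol-3-yl group on the same nitrogen stays ahead of cyclopropyl, as it did of cyclobutyl, with a 4.2-fold higher number from compound 2 to compound 4 (0.62 log units; beyond the scatter), and compound 2 remains the only compound here whose number is separated from both of the others. Cyclopropylamino in place of cyclopentyloxy reads as an at least 2.1-fold lower number from compound 1 to compound 4 (0.32 log units; beyond the scatter), which is only a bound, since compound 1 carries a limit and not a number: the limit of > 100000 nM in this assay, at which 1 of the 4 values shown sits.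

The compounds shown leave open whether an open-chain isopropyl or a larger cyclohexyl on this nitrogen would read like cyclobutyl and cyclopropyl. Going by these compounds, it also remains open whether a phenyl or a 1H-pyrrol-2-yl there would read like the 1H-pyrrol-3-yl of compound 2.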